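The compounds below may be only part of what the source reports. "The series", "measured", "known", "first", "only" and "open" are said of these compounds alone.

Compound 1 `O=C(Nc1cccc(OCc2ccccc2)c1)C1CCCNC1`, compound 2 `O=C(Nc1ccc(OCc2ccc(F)cc2)cc1)C1CCCNC1` and compound 3 `O=C(Nc1cccc(OCc2ccccc2)c1)C1CCNCC1` share the same kind of amide built on a piperidine ring, and all three have been tested in a functional assay on a cell-free system (Platelet, plasma, Homo sapiens) for inhibition; a higher number here means a weaker inhibitor, a lower number a stronger inhibitor. In this assay compound 1 gives 128000 nM, compound 2 gives 116000 nM and compound 3 gives 229000 nM. Compound 3 differs from compound 1 by piperidin-4-yl in place of piperidin-3-yl on a carbonyl carbon, and that change made a step of a 1.8-fold higher number from compound 1 to compound 3 (0.25 log units; within the scatter). The difference between the cores of compound 1 and compound 2 is not broken down here. Compound 4 `O=C(Nc1ccc(OCc2ccc(F)cc2)cc1)C1CCNCC1` has not yet been measured in this assay. Among the measured compounds shown here, it differs from compound 2 by piperidin-4-yl in place of piperidin-3-yl on a carbonyl carbon, the same change at the same place as the one that took compound 1 to compound 3. Since the earlier change made a 1.8-fold higher number from compound 1 to compound 3 (0.25 log units; within the scatter), a step of about the same size is expected this time, a 1.8-fold higher number from compound 2 to compound 4 (0.26 log units; within the scatter). On that basis compound 4 is estimated at 210000 nM in this assay, most likely between 90000 nM and 450000 nM. This rests on a single earlier example of the change, so the range is kept wide.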

Compound 4, half-maximal inhibitory concentration: 121000 nM
Compound 4: middle estimate off by 1.7-fold (0.24 log units), on the high side; the measured number falls inside the stated range.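

In this assay, piperidin-4-yl in place of piperidin-3-yl on the carbonyl carbon made a step of a 1.0-fold higher number from compound 2 to compound 4 (0.02 log units; within the scatter). Set beside the earlier example of the same change, the two steps agree as closely as repeated measurements would allow: the same change on two cores in this assay, a 1.8-fold higher number (0.25 log units; within the scatter) from compound 1 to compound 3 and a 1.0-fold higher number (0.02 log units; within the scatter) from compound 2 to compound 4, 1.7-fold (0.23 log units) apart, within the scatter of two such steps. On these two cores, then, the change can be carried from one to the other with no sign that the core alters its result, but each step is itself within the scatter, so this does not show that the change has a real effect on either core, and two examples cannot show how it would behave on other cores in the series.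

The compounds shown leave open what a different group on the carbonyl carbon would do, such as an open-chain amine or a carboxylic acid in place of the piperidine ring. They also leave open whether a methyl group on the piperidine nitrogen would move the number beyond the scatter.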